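Amide variation on a shared core

The source may report more compounds than this note shows. Statements on the series, on what has been measured and on what is new or still open speak of the compounds shown alone.

Compound 1 `COc1ccc2c(c1)OC(c1cc(OC)c(OC)c(OC)c1)C(C(=O)N(C)C)=C2`: > 50000 nM
Compound 2 `COc1ccc2c(c1)OC(c1cc(OC)c(OC)c(OC)c1)C(/C=N/O)=C2`: 14100 nM
Compound 3 `COc1ccc2c(c1)OC(c1cc(OC)c(OC)c(OC)c1)C(C(=O)NC(C)C)=C2`: > 50000 nM

All three were tested in a functional assay for inhibition of nuclear factor NF-kappa-B complex (Homo sapiens); a lower number here means a stronger inhibitor, a higher number a weaker inhibitor. Compound 3 gives only a limit of the assay, not a number, at > 50000 nM. Compound 1 sits at the same limit, as the limit of > 50000 nM in this assay, at which 2 of the 3 values shown sit, shows, so the step that the two limits leave unreadable from compound 1 to compound 3 cannot be read. Only the oxime, compound 2, gives a number, and the steps of an at least 3.5-fold lower number from compound 1 to compound 2 (0.54 log units; beyond the scatter) and an at least 3.5-fold higher number from compound 2 to compound 3 (0.54 log units; beyond the scatter) show both amides weaker than it.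

Compound 4 `COc1ccc2c(c1)OC(c1cc(OC)c(OC)c(OC)c1)C(C(=O)N1CCCCC1)=C2` differs from compound 3 by piperidin-1-yl in place of isopropylamino on a carbonyl carbon. With both neighbouring amides at the limit, a third amide is expected to stay there too, so compound 4 is estimated at 60000 nM, within 20000 nM to 200000 nM, an expected step that the limit leaves unreadable from compound 3 to compound 4.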

Compound 4, half-maximal inhibitory concentration: > 50000 nM
Compound 4 was reported as a limit; the forecaster's own chance of this, stated with the estimate: 80%; the middle value does not contradict the limit.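

In this assay compound 4 also gives only a limit of the assay (> 50000 nM). A six-membered ring on the amide nitrogen therefore brings no measurable inhibition either, and the oxime stays ahead of this amide too (an at least 3.5-fold higher number from compound 2 to compound 4 (0.54 log units; beyond the scatter)). The steps among the three amides cannot be read, because all of them sit at one limit: the limit of > 50000 nM in this assay, at which 3 of the 4 values shown sit.

From the compounds shown here alone, it remains open how far the amides really lie from the oxime. Going by these compounds, it is also open whether a carboxylic acid or a nitrile on the double-bonded ring carbon would give a number.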